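The source may hold more compounds than are shown below. What is called first, only, known or untested is meant among the compounds shown, and "the series" means these compounds.

The series shares one core, seen in compound 1 `C[C@H](NC(=O)CN(c1nc(Cl)nc2[nH]cnc12)C1CC1)C(=O)O`, compound 2 `O=C(O)C[C@H](NC(=O)CN(c1nc(Cl)nc2[nH]cnc12)C1CC1)C(=O)O` and compound 3 `NC(=O)C[C@H](NC(=O)CN(c1nc(Cl)nc2[nH]cnc12)C1CC1)C(=O)OCc1ccccc1`. In a functional assay on the whole organism (Tail, strain ICR) with Mus musculus as the target, in the tail flick test, with a stated time of 60 min, at a dose of 25 umol/kg by the oral route (a higher number here means a stronger effect of the compound at the dose given, a lower number a weaker effect), compound 1 gives 44.6%, compound 2 gives 38.9% and compound 3 gives 36.4%; the number for compound 3 lies within the scatter of each of the other two. Within the data shown here, the only single-point step measured so far, a number 5.7 percentage points lower from compound 1 to compound 2 (within the scatter), brings in a carboxy and moves the read-out by nothing beyond the scatter. Compound 4 `NC(=O)C[C@H](NC(=O)CN(c1nc(Cl)nc2[nH]cnc12)C1CC1)C(=O)O` is compound 3 with hydrogen in place of benzyl on an oxygen next to a carbonyl group. Among the measured compounds shown here, no measured step exchanges a benzyl for hydrogen on an oxygen next to a carbonyl group, so nothing in the data speaks to this change directly; the step expected in this assay is a number 1.6 percentage points higher from compound 3 to compound 4 (within the scatter), nothing beyond the scatter. Compound 4 is therefore expected to give 38% in this assay, within the range 24% to 52%.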

Compound 4, a percentage reported as activity, at one dose (the size of the read-out at that dose, not a potency): 43.1%
Estimate against measurement, compound 4: 5.1 percentage points below, and the stated range covers the measured number.
By their numbers in this assay, from the lowest: compounds 3, 2, 4 and 1 (each within the scatter of the next).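

Exchanging benzyloxycarbonyl for carboxy gives a number 6.7 percentage points higher from compound 3 to compound 4 (within the scatter) in this assay and so leaves the read-out at this dose unchanged within the scatter. The carbamoyl side chain also stays within the scatter of both neighbours, with a number 4.2 percentage points higher from compound 2 to compound 4 (within the scatter) for amino in place of hydroxy and a number 1.5 percentage points lower from compound 1 to compound 4 (within the scatter) for carbamoyl in place of hydrogen. No supporting data bear on these results.

As far as these compounds go, whether a methyl ester in place of the benzyloxycarbonyl, or an amine or a longer chain in place of the carbamoyl, would move the read-out beyond the scatter remains open.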